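Swapping the amide substituent: compound 2 to compound 3

The source may report more compounds than this note shows. Statements on the series, on what has been measured and on what is new or still open speak of the compounds shown alone.

Two compounds share one core and differ only in the group attached to a carbonyl carbon. Compound 1 `COc1cc2nccc(Oc3ccc(Nc4nn(C)cc4C(=O)Nc4ccccc4F)cc3)c2cc1C(N)=O` gives 1710 nM in a functional assay on BaF3 cells (Mus musculus) for antiproliferative activity, read by CCK-8 assay and cell counting, with a stated time of 76 h; on this read-out lower numbers stand for stronger inhibition and higher numbers for weaker inhibition. Compound 2 `COc1cc2nccc(Oc3ccc(Nc4nn(C)cc4C(=O)N4CCCCC4)cc3)c2cc1C(N)=O` gives 5650 nM in this assay, which is the higher of the two numbers, so compound 2 is the weaker inhibitor. Going by the values given here, the one measured step, a 3.3-fold higher number from compound 1 to compound 2 (0.52 log units; beyond the scatter), came with piperidin-1-yl in place of (2-fluorophenyl)amino on the carbonyl carbon. Compound 3 `COc1cc2nccc(Oc3ccc(Nc4nn(C)cc4C(=O)NC4CCCCC4)cc3)c2cc1C(N)=O` carries the change (cyclohexylamino in place of piperidin-1-yl on a carbonyl carbon). That step bears on the same carbonyl carbon as the measured one and brings back an amino group with a hydrogen-bond donor, though with a saturated ring rather than the aromatic one of compound 1, so only part of the earlier loss is expected to be recovered. A modest decrease in the number, a 2.0-fold lower number from compound 2 to compound 3 (0.30 log units; within the scatter), is therefore expected for compound 3. Compound 3 is estimated to give 2800 nM, within a range from 1200 nM to 6500 nM.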

Compound 3, half-maximal inhibitory concentration: 4800 nM
Compound 3: the middle estimate sits 1.7-fold (0.23 log units) below what was measured; the measured number falls inside the stated range.
By their numbers in this assay, from the lowest: compound 1; then compounds 3 and 2 (each within the scatter of the next).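

In this assay, cyclohexylamino in place of piperidin-1-yl on the carbonyl carbon gives a 1.2-fold lower number from compound 2 to compound 3 (0.07 log units; within the scatter), so restoring the amide hydrogen with a saturated ring does not separate these two compounds. With the amide hydrogen present in both, cyclohexyl in place of 2-fluorophenyl on the amide-type nitrogen gives a 2.8-fold higher number from compound 1 to compound 3 (0.45 log units; beyond the scatter), so among these three compounds the lowest number goes with the 2-fluorophenyl group, not with the amide hydrogen alone. No measurement available here explains this difference.

From the compounds shown here alone, how a plain phenyl group on the same nitrogen would compare remains open, so the contributions of the aromatic ring and its fluorine cannot yet be told apart. Also open, going by these compounds, is how a morpholin-4-yl group would read in place of piperidin-1-yl on the carbonyl carbon.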